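A Ring Swap at the Low End of Three Numbers

A few compounds are considered here, and "the series" means these few. Any claim that something is new, unique, unknown or untested is made for them only; others in the source may bear on it.

Three related compounds have been tested in an in vivo ADME assay on the whole organism (strain 129/SvEvBrd x C57BL/6) for pharmacokinetics, with Mus musculus as the target; a lower number here means that a smaller share of the oral dose reaches the circulation, a higher number that a larger share of the oral dose reaches the circulation. Compound 1 `CC(=O)c1ncc([C@@H](O)[C@H](O)[C@H](O)CO)s1` gives 65%, compound 2 `CC(=O)c1nc([C@@H](O)[C@H](O)[C@H](O)CO)c(-c2ccccc2)[nH]1` gives 49.6%, and compound 3 `OC[C@@H](O)[C@@H](O)[C@H](O)c1c[nH]c(-c2cscn2)n1` gives 12%. Compound 3 is the lowest of the three, and its gaps to both of the others lie beyond the usual scatter of such measurements.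

Compound 4 `OC[C@@H](O)[C@@H](O)[C@H](O)c1c[nH]c(-c2ncon2)n1` has not been measured yet. It differs from compound 3 in a single group: 1,2,4-oxadiazol-3-yl in place of 1,3-thiazol-4-yl on an aromatic carbon. The swap sits on an aromatic carbon of a five-membered aromatic ring with 2 nitrogen, between two ring nitrogen atoms. Both the group that leaves and the group that enters are five-membered aromatic rings with no net charge.

For the measured compounds named here, no two measured compounds differ in only one place, so the data give no direct guide to the size of this step. With compound 3 at 12%, there is little room to fall, so a modest rise seems more likely than a drop, although a change within the scatter remains quite possible. The expected step is a number 12 percentage points higher from compound 3 to compound 4 (beyond the scatter). For compound 4 the estimated value is 24%, with an expected range from 8% to 50%.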

Compound 4, oral bioavailability: 5%
Compound 4: the middle estimate sits 19 percentage points above what was measured, outside the stated range (below it).
By their numbers in this assay, from the lowest: compounds 4 and 3 (each within the scatter of the next); then compound 2; then compound 1.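

For the compounds shown here, this is the first pair in the set that differs in only one place, so it gives the first direct reading of this position. In this assay, putting 1,2,4-oxadiazol-3-yl in place of 1,3-thiazol-4-yl gives a number 7 percentage points lower from compound 3 to compound 4 (within the scatter), so this swap on an aromatic carbon, between two ring nitrogen atoms, cannot be told apart from the normal spread of repeated measurements. The two groups have the same number of heavy atoms and are both uncharged five-membered aromatic rings, although the entering ring has one more hetero atom and one more hydrogen-bond acceptor; at this position, those differences leave no change that can be read in the share of the oral dose reaching the circulation, and no measurement at hand speaks to what lies behind this result.

Both compounds carry a five-membered aromatic ring here, so the pair says nothing about how a quite different group at the same place, such as an amine, a carboxylic acid or a phenyl ring, would fare. It also leaves open whether the same swap would give so small a step on the core of compound 1 or compound 2.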